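Changing the aryl group from compound 3 to compound 4

The source may hold more compounds than are shown below. What is called first, only, known or untested is meant among the compounds shown, and "the series" means these compounds.

In a functional assay on SK-OV-3 cells (Homo sapiens) for antiproliferative activity, read by MTT assay, with a stated time of 72 h (a higher number here means a weaker inhibitor of growth, a lower number a stronger inhibitor of growth), compound 3 (`Cc1ccc(Cl)c(-n2nnc(C(=O)Nc3ccc(SC#N)cc3)c2C)c1`) gives 9600 nM and compound 1 (`Cc1c(C(=O)Nc2ccc(SC#N)cc2)nnn1-c1ccc(C(C)C)cc1`) gives 10000 nM, level within the scatter, as a 1.0-fold lower number from compound 1 to compound 3 (0.02 log units; within the scatter) shows. Compound 2 (`Cc1ccc(Cl)cc1-n1nnc(C(=O)Nc2ccc(SC#N)cc2)c1C`) gives 81500 nM and stands apart from both.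

Next comes compound 4 (`COc1cccc(-n2nnc(C(=O)Nc3ccc(SC#N)cc3)c2C)c1`), with 3-methoxyphenyl in place of 2-chloro-5-methylphenyl on an aromatic nitrogen.

All measured steps changed this same group. Two were modest, an 8.2-fold higher number from compound 1 to compound 2 (0.91 log units; beyond the scatter) and an 8.5-fold lower number from compound 2 to compound 3 (0.93 log units; beyond the scatter), and both involve compound 2. None tests a methoxy group, so the size of the coming step stays uncertain. Expected is a 1.3-fold higher number from compound 3 to compound 4 (0.10 log units; within the scatter), no step beyond the scatter. For compound 4 the estimate is 12000 nM, with an expected range of 4500 nM to 35000 nM.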

Compound 4, concentration for 50% growth inhibition: 64600 nM
For compound 4 the middle estimate is 5.4-fold (0.73 log units) below the measured one; the measured number lies above the stated range.
By their numbers in this assay, from the lowest: compounds 3 and 1 (each within the scatter of the next); then compounds 4 and 2 (each within the scatter of the next).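

At this position, 3-methoxyphenyl falls on the weaker level of the series, with a 6.7-fold higher number from compound 3 to compound 4 (0.83 log units; beyond the scatter) and a 6.5-fold higher number from compound 1 to compound 4 (0.81 log units; beyond the scatter), whereas a 1.3-fold lower number from compound 2 to compound 4 (0.10 log units; within the scatter). Chlorine does not sort the four aryl groups: each level now holds one aryl group with chlorine and one without. As far as these compounds go, whether an amine or a carboxylic acid on this aryl ring, or a longer chain in place of the methoxy group, would return the number to the level of compound 3 stays open. Nothing available accounts for the gap between the two levels.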